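Swapping bromo for chloro in compound 2

A few compounds are considered here, and "the series" means these few. Any claim that something is new, unique, unknown or untested is made for them only; others in the source may bear on it.

Compound 1 `COc1ccc(/C=C(\C)C(=O)/C=C/c2cccc(Br)c2)cc1`: 153000 nM
Compound 2 `COc1ccc(/C=C(\C)C(=O)/C=C/c2ccc(Br)cc2)cc1`: 31200 nM
Compound 3 `COc1ccc(/C=C(\C)C(=O)/C=C/c2ccc(Cl)cc2)cc1`: not yet measured

Within the data shown here, in an ADME assay on Vero cells (Chlorocebus sabaeus) for cytotoxicity, read by MTT assay, with a stated time of 72 h (on this read-out lower numbers stand for higher toxicity in this test and higher numbers for lower toxicity in this test), compound 2 gives 31200 nM, the lower of the two numbers so far. Compound 3 differs from it at one place: chloro in place of bromo on an aromatic carbon. Among the measured compounds shown here, the only measured step, a 4.9-fold lower number from compound 1 to compound 2 (0.69 log units; beyond the scatter), put 4-bromophenyl in place of 3-bromophenyl and exchanged no halogen, so it bears only loosely on this change. No shift beyond the scatter is therefore expected in this assay. The expected step is a 1.2-fold higher number from compound 2 to compound 3 (0.09 log units; within the scatter). For compound 3 the estimate is 38000 nM, with an expected range from 15000 nM to 95000 nM.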

Compound 3, half-maximal cytotoxic concentration: 87000 nM
Beside the measured number, compound 3's estimate is 2.3-fold (0.36 log units) below it, and the stated range covers the measured number.
By their numbers in this assay, from the lowest: compound 2; then compounds 3 and 1 (each within the scatter of the next).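

In this assay, the halogen itself matters at this position, on an aromatic carbon para to a large group: chloro in place of bromo gives a 2.8-fold higher number from compound 2 to compound 3 (0.45 log units; beyond the scatter), so a change of element, with the ring place held fixed, moves the number. By contrast, a 1.8-fold lower number from compound 1 to compound 3 (0.25 log units; within the scatter) leaves 4-chlorophenyl and 3-bromophenyl unresolved in this test. Nothing available explains the halogen effect.

From the compounds shown here alone, it remains open how fluoro, iodo or an amine at this place would read, and whether 3-chlorophenyl would follow the same halogen trend.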